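Acetamido for Ethoxy on a Biaryl Amide Series

The compounds below may be only part of what the source reports. "The series", "measured", "known", "first", "only" and "open" are said of these compounds alone.

Measured compounds in a functional assay for agonist activity at G protein-coupled receptor 88 (Homo sapiens), read by HTRF and cAMP accumulation; on this read-out higher numbers stand for an effect only at larger amounts of compound and lower numbers for an effect already at smaller amounts:
Compound 1, `CC[C@H](C)[C@H](N)CN(C(=O)[C@@H]1C[C@H]1c1cccc(Cl)c1)c1ccc(-c2ccccc2)cc1`, gives 2200 nM.
Compound 2, `CCOc1ccc(-c2ccc(N(C[C@@H](N)[C@@H](C)CC)C(=O)[C@@H]3C[C@H]3c3ccccc3)cc2)cc1`, gives 90 nM.

Of the two numbers, compound 2 holds the lower, and compound 1 sits higher by a margin beyond the scatter. Compound 3, `CC[C@H](C)[C@H](N)CN(C(=O)[C@@H]1C[C@H]1c1ccccc1)c1ccc(-c2ccc(NC(C)=O)cc2)cc1`, has not been measured. It differs from compound 2 in one place: acetamido in place of ethoxy on an aromatic carbon. Among the compounds with values here, no step of this kind has been measured here, so the size of the change is uncertain. Compound 3 is expected to show a modest rise, a 2.8-fold higher number from compound 2 to compound 3 (0.44 log units; beyond the scatter), and its value is estimated at 250 nM, within 60 nM to 1000 nM.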

Compound 3, half-maximal effective concentration: 5500 nM
Compound 3: middle estimate off by 22-fold (1.34 log units), on the low side; measured number above the stated range.
By their numbers in this assay, from the lowest: compound 2; then compound 1; then compound 3.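

In this assay, acetamido in place of ethoxy on this aromatic carbon, para to a large group, gives a 61-fold higher number from compound 2 to compound 3 (1.79 log units; beyond the scatter) and so shows that the position is far from indifferent to what it carries. A single change here is enough to move compound 3 well away from compound 2. No measurement shown accounts for this step.

From the compounds shown here alone, whether the amide hydrogen or the carbonyl of acetamido matters more stays open. So does how a methoxy group, a propoxy chain or a primary amine would read at this position.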